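A few compounds are considered here, and "the series" means these few. Any claim that something is new, unique, unknown or untested is made for them only; others in the source may bear on it.

Of the compounds shown here, three sharing one core have been tested in a functional assay on the whole organism (B cells) with Mus musculus as the target; a lower number here means a smaller maximal response, a higher number a larger maximal response. Compound 1 `C=CCn1c(=S)n(C2OC(CO)[C@@H](O)C(O)[C@H]2O)c2nc(N)nc(O)c21` gives 5% in this assay. Compound 2 `Nc1nc(O)c2c(n1)n(C1OC(CO)[C@@H](O)[C@H]1O)c(=O)n2CC(O)CN1CCN(c2ccc(F)cc2)CC1` gives 16% in this assay. Compound 3 `NC(=O)Cn1c(=O)n(C2OC(CO)[C@@H](O)[C@H]2O)c2nc(N)nc(O)c21` gives 32% in this assay, the highest of the three numbers: its nearest neighbour is compound 2, whose number lies below it by more than the scatter, and compound 1 lies furthest below, also beyond the scatter. Among the compounds with values here, no pair of these three compounds differs in only one place, so no single step can be read from them. Compound 4 `Cn1c(=O)n(C2OC(CO)[C@@H](O)[C@H]2O)c2nc(N)nc(O)c21` has not yet been measured. It differs from compound 3 in one place: hydrogen in place of carbamoyl on a saturated chain carbon bound to an aromatic nitrogen. Within the data shown here, nothing among the measured compounds shows what such a change does to the maximal response, so the expectation rests on compound 3 alone. In this assay the expected step is a number 10 percentage points lower from compound 3 to compound 4 (within the scatter), a modest fall, though a result within the scatter would not surprise. Compound 4 is estimated to give 22% in this assay, with 5% and 40% as the ends of its range.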

Compound 4, largest response reached (reported as maximal response), in percent of the reference or control that the assay uses: 99%
The estimate for compound 4 lay 77 percentage points below the measured number, outside the stated range (above it).
By their numbers in this assay, from the lowest: compound 1; then compound 2; then compound 3; then compound 4.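

Shortening carbamoylmethyl to methyl is the first single change that can be read at this place, and in this assay it gives a number 67 percentage points higher from compound 3 to compound 4 (beyond the scatter). The step shows that the maximal response is highly sensitive to what sits on a saturated chain carbon bound to an aromatic nitrogen: losing carbamoyl alone, with the rest of the molecule unchanged, moves the number this far. No measurement shown here gives a reason for this step.

One pair cannot tell whether carbamoyl specifically holds the response down or whether any group larger than hydrogen at this place would do the same. An ethyl chain or a carboxylic acid at this place would show whether the high response belongs to methyl alone or extends to other groups.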